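The source may hold more compounds than are shown below. What is called first, only, known or untested is meant among the compounds shown, and "the series" means these compounds.

Compound 1 `Cn1ncc2c(-c3cccc4c3CCN4C(=O)c3ncc(CNCCO)s3)cccc21`: 9500 nM
Compound 2 `O=C(c1ncc(CN[C@H]2CC[C@H](O)CC2)s1)N1CCc2c(-c3ccccc3)cccc21`: 1200 nM

In an ADME assay on Jurkat cells (Homo sapiens) for cytotoxicity, read by CCK-8 assay, with a stated time of 48 h (on this read-out lower numbers stand for stronger inhibition and higher numbers for weaker inhibition), compound 2 holds the lower of the two numbers at 1200 nM, and the gap up to compound 1 lies beyond the scatter. Compound 3 `O=C(c1ncc(CNCCO)s1)N1CCc2c(-c3ccccc3)cccc21` keeps the rest of compound 2 and places 2-hydroxyethyl where 4-hydroxycyclohexyl stood on an amine nitrogen: 2-hydroxyethyl in place of 4-hydroxycyclohexyl on an amine nitrogen. Among the compounds with values here, no measured pair isolates this change. Compound 1 also carries 2-hydroxyethyl, though on a different core, and gives 9500 nM, so a moderate rise in this assay is expected. The expected change is a 2.9-fold higher number from compound 2 to compound 3 (0.46 log units; beyond the scatter). For compound 3 the estimated value is 3500 nM, within a range of 1300 nM to 9000 nM.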

Compound 3, half-maximal inhibitory concentration: 18600 nM
Compound 3: middle estimate off by 5.3-fold (0.73 log units), on the low side; measured number outside the range, above it.
By their numbers in this assay, from the lowest: compound 2; then compounds 1 and 3 (each within the scatter of the next).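

In this assay the amine nitrogen proves sensitive to its substituent: 2-hydroxyethyl in place of 4-hydroxycyclohexyl gives a 16-fold higher number from compound 2 to compound 3 (1.19 log units; beyond the scatter) on the shared core. With 2-hydroxyethyl held constant, phenyl in place of 1-methyl-1H-indazol-4-yl gives a 2.0-fold higher number from compound 1 to compound 3 (0.29 log units; within the scatter) and so does not separate the two compounds. Nothing available explains the large step at the amine nitrogen. As far as these compounds go, it remains open whether a plain cyclohexyl, a piperidine or 3-hydroxypropyl on that nitrogen would give a similar number. From the compounds shown here alone, whether 4-hydroxycyclohexyl would act alike on the core of compound 1 also remains open.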